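Ring Expansion of a Cyclic Amine on the Shared Core

This account rests on a few compounds, and the source may have more. Where it says the series, first, only, none or still open, it means among the compounds named here.

Compound 1 `O=C(/C=C/c1ccc([N+](=O)[O-])o1)c1ccc(I)cc1`: 2100 nM
Compound 2 `CCCCc1ccc(C(=O)/C=C/c2ccc([N+](=O)[O-])o2)cc1`: 1700 nM
Compound 3 `O=C(/C=C/c1ccc([N+](=O)[O-])o1)c1ccc(N2CCCC2)cc1`: 16400 nM

In a functional assay on C6 cells (Rattus norvegicus) for inhibition, read by sulforhodamine B assay, with a stated time of 72 h (on this read-out lower numbers stand for an effect already at smaller amounts and higher numbers for an effect only at larger amounts of compound), compound 3 stands at the highest number of the three: the steps of a 7.8-fold higher number from compound 1 to compound 3 (0.89 log units; beyond the scatter) and a 9.6-fold higher number from compound 2 to compound 3 (0.98 log units; beyond the scatter) are both beyond the scatter, whereas a 1.2-fold lower number from compound 1 to compound 2 (0.09 log units; within the scatter) stays within it. Compound 4 `O=C(/C=C/c1ccc([N+](=O)[O-])o1)c1ccc(N2CCCCC2)cc1` differs from compound 3 only by piperidin-1-yl in place of pyrrolidin-1-yl on an aromatic carbon. For the measured compounds named here, no measured step swaps one cyclic amine for another; the two steps that end at compound 3 show only that the pyrrolidin-1-yl group sits at a higher number than iodo or butyl. Moving from the five-membered to the six-membered ring is a small change, so the expected step of a 1.2-fold lower number from compound 3 to compound 4 (0.07 log units; within the scatter) is judged to lie within the scatter. Compound 4 is therefore estimated at 14000 nM, with a range from 6000 nM to 35000 nM.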

Compound 4, half-maximal effective concentration: 48700 nM
Estimate against measurement, compound 4: 3.5-fold (0.54 log units) below, outside the stated range (above it).
By their numbers in this assay, from the lowest: compounds 2 and 1 (each within the scatter of the next); then compound 3; then compound 4.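

In this assay, swapping one cyclic amine for another at this position is no silent change: a 3.0-fold higher number from compound 3 to compound 4 (0.47 log units; beyond the scatter) comes with piperidin-1-yl in place of pyrrolidin-1-yl. Against the other groups, piperidin-1-yl gives large steps, a 29-fold higher number from compound 2 to compound 4 (1.46 log units; beyond the scatter) from butyl and a 23-fold higher number from compound 1 to compound 4 (1.37 log units; beyond the scatter) from iodo, so the size of the ring moves the number here, not only the presence of a cyclic amine. No measurement at hand accounts for the gap between the two rings. On these data alone, it stays open where morpholin-4-yl or an open-chain diethylamino group would fall at this position on the shared core.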